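Phenyl in Place of Pyridine: Compound 2 to Compound 3

A few compounds are considered here, and "the series" means these few. Any claim that something is new, unique, unknown or untested is made for them only; others in the source may bear on it.

Compound 2 `CCN(Cc1ccccn1)c1ccc(C(=O)N2CCc3ccc(OS(N)(=O)=O)cc3C2)cc1` stands highest of the two measured compounds: in an assay on HEK293 cells for inhibition of Steryl-sulfatase (Homo sapiens), tested at 0.1 uM (a lower number here means a weaker effect, a higher number a stronger effect of the compound at the concentration tested), compound 2 gives 42.5%. Compound 1 `CCN(Cc1ccccc1)c1cccc(C(=O)N2CCc3ccc(OS(N)(=O)=O)cc3C2)c1` gives 17.3% in this assay, and the gap between these two numbers lies beyond the usual scatter of the measurement. Compound 3 `CCN(Cc1ccccc1)c1ccc(C(=O)N2CCc3ccc(OS(N)(=O)=O)cc3C2)cc1` has not yet been measured. It differs from compound 2 in one place: phenyl in place of pyridin-2-yl on a saturated chain carbon bound to a nitrogen on an aromatic ring. Among the compounds with values here, no pair of measured compounds shows this exchange on its own, so its size cannot be read from the measured numbers; the change is small in atom count, with one hydrogen-bond acceptor leaving and none entering. The step from compound 2 to compound 3 is therefore expected to be modest, if anything slightly downward, amounting to a number 4.5 percentage points lower from compound 2 to compound 3 (within the scatter) in this assay. For compound 3 the estimate is 38% in this assay, with a range from 22% to 56%.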

Compound 3, a percentage reported as inhibition, at one concentration (the size of the read-out at that concentration, not a potency): 66.9%
Beside the measured number, compound 3's estimate is 28.9 percentage points below it; the measured number lies above the stated range.
By their numbers in this assay, from the lowest: compound 1; then compound 2; then compound 3.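

At this position, the exchange of pyridin-2-yl for phenyl matters: in this assay it gives a number 24.4 percentage points higher from compound 2 to compound 3 (beyond the scatter). Both groups are six-membered aromatic rings with the same count of heavy atoms, so the step shows that replacing the single ring nitrogen with carbon, which also removes a hydrogen-bond acceptor, is enough to move the number clearly. No measurement here explains why the all-carbon ring gives the higher number.

The compounds shown leave open whether pyridin-3-yl, with its ring nitrogen placed differently, would behave more like pyridin-2-yl or like phenyl. They also leave open what a chlorine atom or a methoxy group on the phenyl would do, and whether cyclohexyl, a saturated six-membered ring, could take the place of phenyl.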